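Chain Lengthening in Hydroxamate Growth Inhibitors

The compounds below may be only part of what the source reports. "The series", "measured", "known", "first", "only" and "open" are said of these compounds alone.

Compound 1 `C#CCN(C)Cc1cccc(NC(=O)CCC(=O)NO)c1`, compound 2 `C#CCN(C)Cc1cccc(NC(=O)CCCC(=O)NO)c1` and compound 3 `C#CCN(C)Cc1ccc(NC(=O)CCCCCC(=O)NO)cc1` were tested in a functional assay on DU-145 cells (Homo sapiens) for inhibition, read by MTT assay, with a stated time of 48 h; a higher number here means a weaker inhibitor of growth, a lower number a stronger inhibitor of growth. In this assay compound 1 gives > 10000 nM, which is a limit of the assay and not a number. Compound 2 gives > 10000 nM, again a limit. Compound 3 gives > 10000 nM, also a limit. The change from compound 1 to compound 2 is (hydroxycarbamoyl)methyl in place of hydroxycarbamoyl on a saturated chain carbon, two bonds along the chain from a carbonyl carbon, and its step that the two limits leave unreadable from compound 1 to compound 2 is unreadable because of the limit of > 10000 nM in this assay, at which 3 of the 3 values shown sit. Compound 4 `C#CCN(C)Cc1ccc(NC(=O)CCCCCCC(=O)NO)cc1` arises from compound 3 by the same kind of change, ((hydroxycarbamoyl)methyl in place of hydroxycarbamoyl on a saturated chain carbon, five bonds along the chain from a carbonyl carbon), but at a different place along the chain. The difference between the cores of compound 1 and compound 3 is not broken down here. The step to compound 4 is expected as an at least 2.5-fold lower number from compound 3 to compound 4 (0.39 log units; beyond the scatter), resting only on compound 3 at > 10000 nM. Compound 4 is estimated at 4000 nM, between 1000 nM and 15000 nM.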

Compound 4, concentration for 50% growth inhibition: 1510 nM
Estimate against measurement, compound 4: 2.6-fold (0.42 log units) above, within the range that was stated.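

On the core of compound 3, this chain lengthening gives an at least 6.6-fold lower number from compound 3 to compound 4 (0.82 log units; beyond the scatter) in this assay, so on that core the change is followed by stronger growth inhibition. Compound 3 gives > 10000 nM, which is a limit of the assay and not a number. This does not show that the change carries from one core to another, since the same kind of change on the core of compound 1 cannot be read, and neither can any other step at this limit: the limit of > 10000 nM in this assay, at which 3 of the 4 values shown sit.

Still open, from the compounds shown here alone, is whether a longer chain than that of compound 4 would lower the number further. Also open, going by these compounds, is whether a carboxylic acid in place of the hydroxycarbamoyl group would keep any growth inhibition.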